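From fluoro to trifluoromethoxy at an assay limit

The compounds below may be only part of what the source reports. "The series", "measured", "known", "first", "only" and "open" are said of these compounds alone.

Measured in an ADME assay on Raji cells (Homo sapiens) for cytotoxicity, with a stated time of 72 h; a lower number here means that less compound is needed, a higher number that more compound is needed for the effect:
- compound 1 `Cc1cc(NC(=O)Nc2ccccc2N)c2ccccc2n1`: > 25000 nM
- compound 2 `Cc1cc(NC(=O)Nc2ccc(F)c(F)c2)c2ccccc2n1`: > 25000 nM
- compound 3 `Cc1cc(NC(=O)Nc2ccc(F)cc2)c2ccccc2n1`: > 25000 nM

Each of these entries is a limit of the assay and not a number. Compound 3 stands at > 25000 nM, and this too is only a limit.

Compound 4 `Cc1cc(NC(=O)Nc2ccc(OC(F)(F)F)cc2)c2ccccc2n1` changes one group of compound 3, with trifluoromethoxy in place of fluoro on an aromatic carbon.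

The closest measured change is a step that the two limits leave unreadable from compound 2 to compound 3, which also swaps a group on an aromatic carbon. The other is a step that the two limits leave unreadable from compound 1 to compound 3. Neither has a size that can be read, so neither can say how far a new group might move the result. What the data do show is the limit of > 25000 nM in this assay, at which 3 of the 3 values shown sit.

No step beyond the usual scatter can be predicted in this assay, and compound 4 is expected to stay at the limit. The expected change is a number no higher from compound 3 to compound 4 (the limit leaves the size open). For compound 4 the estimate is 25000 nM, with an expected range from 10000 nM to 40000 nM.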

Compound 4, half-maximal effective concentration: 10000 nM
Compound 4: the middle estimate sits 2.5-fold (0.40 log units) above what was measured; the measured number falls inside the stated range.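

Among the compounds shown here, at this place, on an aromatic carbon para to a large group, trifluoromethoxy in place of fluoro gives the first step in this assay whose size can be read, namely an at least 2.5-fold lower number from compound 3 to compound 4 (0.39 log units; beyond the scatter) and so less compound is needed for the effect. Compound 3 stands at > 25000 nM and this is a limit of the assay, not a number, so the step has a smallest size but no known full size. Compound 4 is the only compound shown that gives a number instead of a limit: the limit of > 25000 nM in this assay, at which 3 of the 4 values shown sit.

The compounds shown do not tell which part of the entering group goes with this step, since a methoxy or a trifluoromethyl group at the same place would be needed to separate its oxygen from its fluorines. On these data alone, how a group such as an amine or a carboxylic acid would read at this place also stays open.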